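The source may hold more compounds than are shown below. What is called first, only, known or untested is meant among the compounds shown, and "the series" means these compounds.

In a physicochemical assay for solubility (a higher number here means a more soluble compound, a lower number a less soluble compound), compound 1 (`O=C(CN1CCNCC1)N1CCC(NS(=O)(=O)c2cc(S(=O)(=O)c3ccccc3)ccc2C(F)(F)F)CC1`) gives 50000 nM. For the measured compounds named here, compound 2 (`CC(C)(C)C(=O)N1CCC[C@H]1C(=O)N1CCC(NS(=O)(=O)c2cc(S(=O)(=O)c3ccccc3)ccc2C(F)(F)F)CC1`) gives 50000 nM, which places it level with compound 1, its only measured neighbour. Compound 3 (`CN(C)CC(=O)N1CCC[C@H]1C(=O)N1CCC(NS(=O)(=O)c2cc(S(=O)(=O)c3ccccc3)ccc2C(F)(F)F)CC1`) keeps everything in compound 2 except one group: (dimethylamino)methyl in place of tert-butyl on a carbonyl carbon. Put simply, (dimethylamino)methyl stands in place of tert-butyl on a carbonyl carbon, and that carbon's other neighbour is an amide-type nitrogen in a ring. Going by the values given here, only one measured step bears on this change: no change at the digits printed from compound 1 to compound 2 (within the scatter). That step also altered the group on a carbonyl carbon, and its size lies within the scatter. It is a single step, however, and it never tested the (dimethylamino)methyl group. The expectation in this assay is therefore no shift beyond the scatter, with no direction favoured. The estimated step is no change at the digits printed from compound 2 to compound 3 (within the scatter). For compound 3 the estimated value is 50000 nM, with an expected range of 28000 nM to 70000 nM.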

Compound 3, solubility: 100000 nM
Estimate against measurement, compound 3: 2.0-fold (0.30 log units) below; the measured number lies above the stated range.
By their numbers in this assay, from the lowest: compounds 1, 2 and 3 (each within the scatter of the next).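

The new group on this carbonyl carbon, (dimethylamino)methyl, brings a nitrogen and a hydrogen-bond acceptor where tert-butyl has neither, and in this assay the result is a 2.0-fold higher number from compound 2 to compound 3 (0.30 log units; within the scatter) for this swap. The wider replacement, 1-(((dimethylamino)methyl)carbonyl)pyrrolidin-2-yl in place of (piperazin-1-yl)methyl on a carbonyl carbon, gives a 2.0-fold higher number from compound 1 to compound 3 (0.30 log units; within the scatter) in the same read-out, so all three compounds now lie within the scatter of one another. No measurement available here explains this result.

Going by these compounds, whether a carboxylic acid or a longer carbon chain on this carbonyl carbon would give a step beyond the scatter remains open. The same question stands for a morpholine ring carried on the methyl group in place of the dimethylamino group.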